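Swapping a Four-Membered Ring for a Hydroxylated Chain

A few compounds are considered here, and "the series" means these few. Any claim that something is new, unique, unknown or untested is made for them only; others in the source may bear on it.

The measured compounds:
Compound 1 `NS(=O)(=O)CC(=O)NCCSc1nonc1/C(=N/O)Nc1cccc(Br)c1`: in an ADME assay on microsomes from liver (Homo sapiens) for metabolic stability (on this read-out lower numbers stand for a shorter-lived compound and higher numbers for a longer-lived compound), compound 1 gives > 3 h, which is a limit of the assay rather than a number.
Compound 2 `CS(=O)(=O)CC(=O)NCCSc1nonc1/C(=N/O)Nc1ccc(F)c(C(F)F)c1`: in this assay compound 2 gives 1.27 h.
Compound 3 `CC1(C(=O)NCCSc2nonc2/C(=N/O)Nc2ccc(F)c(C(F)F)c2)CCN1`: in this assay compound 3 gives 1.97 h.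

Compound 3 holds the higher of the two numbers shown, and its nearest neighbour is compound 2, with a 1.6-fold higher number from compound 2 to compound 3 (0.19 log units; within the scatter). Compound 1 shows only a limit, (the limit of > 3 h in this assay, at which 1 of the 3 values shown sits), and so adds no number to compare against.

Compound 4 `CC(C)(O)CC(=O)NCCSc1nonc1/C(=N/O)Nc1ccc(F)c(C(F)F)c1` differs from compound 3 at one point: a group of 5 heavy atoms (4 carbon, 1 oxygen; no ring) in place of a group of 5 heavy atoms (4 carbon, 1 nitrogen; one four-membered non-aromatic ring with 1 hetero atom), on a carbonyl carbon. Going by the values given here, the only measured step at that same carbonyl carbon, a 1.6-fold higher number from compound 2 to compound 3 (0.19 log units; within the scatter), exchanged a chain for the ring that is now removed again, and it stayed within the scatter. Among the compounds with values here, that step is the single piece of evidence that bears on the present change, and it points to no movement of any size beyond the scatter.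

The number for compound 4 in this assay is therefore expected to stay close to that of compound 3, with an estimated 1.0-fold higher number from compound 3 to compound 4 (0.01 log units; within the scatter). Compound 4 is estimated at 2 h, with a range from 1 h to 4 h.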

Compound 4, half-life: 0.937 h
Compound 4: middle estimate off by 2.1-fold (0.33 log units), on the high side; measured number below the stated range.
By their numbers in this assay, from the lowest: compounds 4, 2 and 3 (each within the scatter of the next, the first and the last beyond it). At a limit, above all of these: compound 1.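

Going by these compounds alone, on the carbonyl carbon, the choice of group does register in this assay: replacing the four-membered ring with 2-hydroxy-2-methylpropyl gives the first step at this place to pass beyond the scatter, though only a modest one (a 2.1-fold lower number from compound 3 to compound 4 (0.32 log units; beyond the scatter)). The hydroxylated chain and the methylsulfonyl-bearing chain, by contrast, cannot be told apart (a 1.4-fold lower number from compound 2 to compound 4 (0.13 log units; within the scatter)), so compound 3 stands clear of compound 4 while remaining within the scatter of compound 2, and the three compounds do not fall into two clean groups of ring and chain. Nothing in the data shown gives a reason for the step from the ring to the hydroxylated chain.

Going by these compounds, it stays open whether the number for compound 3 goes with the ring as such or with its nitrogen, a question that an open-chain amine or an all-carbon four-membered ring on the same carbonyl carbon would help to settle. On these data alone, it also stays open how a carboxylic acid or a longer chain would read at this place, and whether the modest step would hold with another group on the aromatic ring of the shared core.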